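A few compounds are considered here, and "the series" means these few. Any claim that something is new, unique, unknown or untested is made for them only; others in the source may bear on it.

Compounds 1, 2 and 3 share one core and differ only in a single group on an aromatic carbon. In a functional assay on PC-3 cells (Homo sapiens) for inhibition, read by MTT assay, with a stated time of 48 h (a lower number here means a stronger inhibitor, a higher number a weaker inhibitor), compound 1 (`COc1ccc(Nc2nnc(Cl)c(Nc3cc(OC)c(OC)c(OC)c3)n2)cc1`) gives 13500 nM as its value, compound 2 (`COc1cc(Nc2nc(Nc3ccc(C)cc3)nnc2Cl)cc(OC)c1OC`) gives 14300 nM as its value, and compound 3 (`COc1cc(Nc2nc(Nc3ccc(Br)cc3)nnc2Cl)cc(OC)c1OC`) gives 8990 nM as its value. Compound 3 thus stands level with the other two, with both of its gaps inside the scatter. Compound 4 (`COc1cc(Nc2nc(Nc3ccc4c(ccn4C)c3)nnc2Cl)cc(OC)c1OC`) carries 1-methyl-1H-indol-5-yl in place of 4-bromophenyl on a nitrogen on an aromatic ring. Going by the values given here, three measured steps bear on this change: (a 1.1-fold higher number from compound 1 to compound 2 (0.03 log units; within the scatter)), (a 1.5-fold lower number from compound 1 to compound 3 (0.18 log units; within the scatter)) and (a 1.6-fold lower number from compound 2 to compound 3 (0.20 log units; within the scatter)). Among the compounds with values here, all three are within the scatter, but each swaps only one group on an aromatic carbon, so they guide this larger replacement only loosely. Within the data shown here, no measured compound carries 1-methyl-1H-indol-5-yl. The estimated step is a 1.0-fold higher number from compound 3 to compound 4 (0.00 log units; within the scatter) and so none beyond the scatter is expected in this assay for now. The estimate for compound 4 is 9000 nM at the middle, with an expected range from 2500 nM to 25000 nM around it.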

Compound 4, half-maximal inhibitory concentration: 48500 nM
Beside the measured number, compound 4's estimate is 5.4-fold (0.73 log units) below it; measured number above the stated range.
By their numbers in this assay, from the lowest: compounds 3, 1 and 2 (each within the scatter of the next); then compound 4.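

In this assay, replacing the substituted phenyl group on this nitrogen with 1-methyl-1H-indol-5-yl weakens inhibition beyond the scatter against all three earlier compounds (a 5.4-fold higher number from compound 3 to compound 4 (0.73 log units; beyond the scatter)), (a 3.4-fold higher number from compound 2 to compound 4 (0.53 log units; beyond the scatter)) and (a 3.6-fold higher number from compound 1 to compound 4 (0.56 log units; beyond the scatter)). The earlier swaps among 4-bromophenyl, 4-methylphenyl and 4-methoxyphenyl all stayed within the scatter, so this position does not accept every aromatic group equally. The compounds shown come with no measurement that explains this loss.

As far as these compounds go, it remains open whether the loss follows from the added five-membered ring itself or from the methyl on its nitrogen, which a comparison with the unmethylated 1H-indol-5-yl group could help separate. From the compounds shown here alone, how an amine or a carboxylic acid on the phenyl ring would behave also remains open.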